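Replacing trifluoromethyl with butyl at the aryl ether

The source may report more compounds than this note shows. Statements on the series, on what has been measured and on what is new or still open speak of the compounds shown alone.

Two sulfonamides sharing one core have been measured. Compound 1 `COc1ccccc1-c1ccc(S(=O)(=O)N2CCC(N3CCC(C)CC3)CC2)cc1` gives 26 nM in a functional assay on DLD-1 cells (Homo sapiens) for antiproliferative activity, read by CellTiter-Glo, with a stated time of 72 h (on this read-out higher numbers stand for weaker inhibition and lower numbers for stronger inhibition), and compound 2 `CC1CCN(C2CCN(S(=O)(=O)c3ccc(OC(F)(F)F)cc3)CC2)CC1` gives 16 nM in this assay. Compound 2 holds the lower of the two numbers, yet the step of a 1.6-fold lower number from compound 1 to compound 2 (0.21 log units; within the scatter) keeps the two compounds within the scatter of each other, so neither can be ranked above the other.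

Compound 3 `CCCCOc1ccc(S(=O)(=O)N2CCC(N3CCC(C)CC3)CC2)cc1` is not yet measured. It differs from compound 2 by butyl in place of trifluoromethyl on an oxygen on an aromatic ring. The only step available, a 1.6-fold lower number from compound 1 to compound 2 (0.21 log units; within the scatter), exchanged the group on the aromatic ring and moved the number little, so the shown data give no sign that this part of the molecule steers the read-out strongly. Compound 3 is therefore expected to land close to compound 2, with the expected step of a 1.4-fold higher number from compound 2 to compound 3 (0.14 log units; within the scatter) lying within the scatter. The estimate for compound 3 is 22 nM, ranging from 8 nM to 65 nM.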

Compound 3, half-maximal inhibitory concentration: 2300 nM
For compound 3 the middle estimate is 100-fold (2.02 log units) below the measured one; measured number above the stated range.
By their numbers in this assay, from the lowest: compounds 2 and 1 (each within the scatter of the next); then compound 3.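

The group on the aromatic oxygen matters far more in this assay than the earlier pair suggested: butyl in place of trifluoromethyl gives a 140-fold higher number from compound 2 to compound 3 (2.16 log units; beyond the scatter), although both groups have the same number of heavy atoms, no ring and no hydrogen-bond donors or acceptors. The butoxy group also separates clearly from 2-methoxyphenyl, with an 88-fold higher number from compound 1 to compound 3 (1.95 log units; beyond the scatter), so this position is not as permissive as the step within the scatter between 2-methoxyphenyl and trifluoromethoxy implied. No measurement shown here explains the large loss of inhibition.

The compounds shown leave open whether the loss follows the length of the chain or the absence of fluorine, a question that a methoxy, an ethoxy or a 2,2,2-trifluoroethoxy group on the same oxygen would address. They also leave open how an amine or a carboxylic acid at the end of such a chain would read out.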